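The source may hold more compounds than are shown below. What is called first, only, known or untested is meant among the compounds shown, and "the series" means these compounds.

Going by the values given here, in a functional assay on the whole organism for inhibition, with Rattus norvegicus as the target (on this read-out lower numbers stand for an effect already at smaller amounts and higher numbers for an effect only at larger amounts of compound), compound 2 (`CCCc1nc(CO)c(C(=O)O)n1Cc1ccc(-c2ccccc2C(=O)O)cc1`) gives 0.069 mg/kg and holds the lowest of the three numbers so far. Compound 3 (`CCCCc1nc(CO)c(C(=O)O)n1Cc1ccc(-c2ccccc2C(=O)O)cc1`) reads 0.22 mg/kg in this assay and compound 1 (`CCCc1nc(C(=O)O)c(C(=O)O)n1Cc1ccc(-c2ccccc2C(=O)O)cc1`) reads 0.67 mg/kg there.

The next structure is compound 4 (`CCCc1nc(CO)c(CO)n1Cc1ccc(-c2ccccc2C(=O)O)cc1`). It differs from compound 2 by hydroxymethyl in place of carboxy on an aromatic carbon, and that carbon sits next to the ring atom that bears a hydroxymethyl group.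

The closest measured precedent is the same swap on a different aromatic carbon, which gave a 9.7-fold lower number from compound 1 to compound 2 (0.99 log units; beyond the scatter) and so hints at a lower number. That single case need not carry over, however, since compounds 1, 2 and 3 all keep the carboxy that leaves here, and no measurement shows what happens without it. The remaining step, a 3.2-fold higher number from compound 2 to compound 3 (0.50 log units; beyond the scatter), concerns the chain and has no direct bearing on this swap.

Weighing these points, a modest rise with wide uncertainty is expected, estimated as a 4.3-fold higher number from compound 2 to compound 4 (0.64 log units; beyond the scatter) in this assay. For compound 4 the expected value is 0.3 mg/kg, with an estimated range from 0.06 mg/kg to 1.5 mg/kg.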

Compound 4, dose for 50% inhibition: 2.1 mg/kg
The estimate for compound 4 lay 7.0-fold (0.85 log units) below the measured number, outside the stated range (above it).
By their numbers in this assay, from the lowest: compound 2; then compound 3; then compound 1; then compound 4.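

In this assay, putting hydroxymethyl in place of carboxy on the aromatic carbon next to the ring nitrogen gives a 30-fold higher number from compound 2 to compound 4 (1.48 log units; beyond the scatter) and leaves compound 4 with the highest number of the four compounds. The same swap on the other aromatic carbon of this ring went the opposite way, with a 9.7-fold lower number from compound 1 to compound 2 (0.99 log units; beyond the scatter), so the outcome of this change depends on which carbon carries it, and the carboxy at this position is strongly tied to a low number. Nothing measured here explains why the two carbons differ so sharply.

The compounds shown leave open whether another group on this carbon, such as a primary amide, a methyl ester or a tetrazole, could stand in for the carboxy, and whether a plain hydrogen there would read closer to compound 2 or to compound 4. They also leave open whether the longer chain of compound 3 would raise the number again when hydroxymethyl sits on both of these ring carbons.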